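The compounds below may be only part of what the source reports. "The series", "measured", "known", "first", "only" and "open" are said of these compounds alone.

Compound 1 `Cc1ncc([N+](=O)[O-])n1CCSC(=S)N1CCC(C)CC1` is one of three dithiocarbamates sharing a nitroimidazole core that were examined in an ADME assay on HeLa cells (Homo sapiens) for cytotoxicity (a higher number here means a weaker inhibitor, a lower number a stronger inhibitor), where compound 1 gives 190 ug/mL. Its two companions are compound 2 `Cc1ncc([N+](=O)[O-])n1CCSC(=S)N1C(C)CCCC1C`, which in this assay gives 130 ug/mL, and compound 3 `Cc1ncc([N+](=O)[O-])n1CCSC(=S)N1CCCC(C)C1`, which gives 170 ug/mL. Compound 1 sits at the top of the three numbers, but the gaps to compound 3 and to compound 2 both fall inside the scatter, so the three compounds cannot be told apart on these data. Among the compounds with values here, the one single-point comparison available, a 1.1-fold lower number from compound 1 to compound 3 (0.05 log units; within the scatter), moves a methyl around the saturated ring and leaves the read-out essentially unchanged.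

Compound 4 `CCOC(=O)C1CCN(C(=S)SCCn2c([N+](=O)[O-])cnc2C)CC1` differs from compound 1 by ethoxycarbonyl in place of methyl on a saturated ring carbon. Within the data shown here, no measured step exchanges a methyl for an ethoxycarbonyl, so nothing in the set speaks directly to this change; the only guidance is that rearranging small substituents on this ring, as from compound 1 to compound 3, stayed within the scatter. On that basis the step from compound 1 to compound 4 is expected to be a 1.1-fold lower number from compound 1 to compound 4 (0.05 log units; within the scatter), that is, no change beyond the scatter. Compound 4 is therefore estimated at 170 ug/mL, with a likely range of 85 ug/mL to 340 ug/mL.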

Compound 4, half-maximal inhibitory concentration: 510 ug/mL
Compound 4: the middle estimate sits 3.0-fold (0.48 log units) below what was measured; measured number outside the range, above it.
By their numbers in this assay, from the lowest: compounds 2, 3 and 1 (each within the scatter of the next); then compound 4.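

In this assay, putting ethoxycarbonyl in place of methyl on the saturated ring carbon, three ring bonds from the ring nitrogen, gives a 2.7-fold higher number from compound 1 to compound 4 (0.43 log units; beyond the scatter), the only step shown here that lies beyond the scatter. The earlier step, a 1.1-fold lower number from compound 1 to compound 3 (0.05 log units; within the scatter), only moved a methyl around the ring and stayed within the scatter, so the read-out does respond to a change on this ring once the group itself is exchanged, and in the direction of a weaker inhibitor. The exchange brings more heavy atoms and two hydrogen-bond acceptors at once, and no measurement at hand accounts for the rise in the number.

Within the data shown here, the single step cannot separate the carbonyl and its oxygens from the sheer length of the group, and a carboxylic acid, a primary amide or a plain propyl chain on the same carbon would be needed to pull those apart. From the compounds shown here alone, it also remains open whether ethoxycarbonyl would do the same on the ring carbon that carries the methyl in compound 3.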